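Urea series, removal of the nitro group

The source may report more compounds than this note shows. Statements on the series, on what has been measured and on what is new or still open speak of the compounds shown alone.

Compound 1 `COc1ccc(-c2cc(=O)c3c(OC)cc(OC)cc3n2Cc2ccccc2)cc1` — in a functional assay on SUP-B15 cells (Homo sapiens) for antiproliferative activity, with a stated time of 72 h (on this read-out higher numbers stand for an effect only at larger amounts of compound and lower numbers for an effect already at smaller amounts), compound 1 gives > 34400 nM, a limit of the assay.
Compound 2 `COC(=O)c1cc(=O)c2cc(NC(=O)Nc3ccc(C(F)(F)F)cc3[N+](=O)[O-])ccc2[nH]1` — in this assay compound 2 gives > 51700 nM, also a limit of the assay.

Compound 2 thus stands only at a limit, as the evidence shows: the limit of > 51700 nM in this assay, at which 1 of the 2 values shown sits. Compound 1 likewise sits at a limit: the limit of > 34400 nM in this assay, at which 1 of the 2 values shown sits. Compound 3 `COC(=O)c1cc(=O)c2cc(NC(=O)Nc3ccc(C(F)(F)F)cc3)ccc2[nH]1` differs from compound 2 by hydrogen in place of nitro on an aromatic carbon. For the measured compounds named here, no step between measured compounds is known, so no change beyond the scatter is expected from compound 2 to compound 3 in this assay. For compound 3 the expected value in this assay is 50000 nM, within 15000 nM to 150000 nM, a step of an at least 1.0-fold lower number from compound 2 to compound 3 (0.01 log units; that floor lies within the scatter) being expected.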

Compound 3, half-maximal effective concentration: 3270 nM
For compound 3 the middle estimate is 15-fold (1.18 log units) above the measured one, outside the stated range (below it).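

On the six-membered aromatic ring of carbon only, at the place ortho to a large group and meta to a trifluoromethyl group, hydrogen instead of nitro gives an at least 15-fold lower number from compound 2 to compound 3 (1.19 log units; beyond the scatter) in this assay. Compound 3 is the only compound shown with a number rather than a limit, and compound 2 stands at a limit. Nothing measured here gives a cause for the step.

Open, going by these compounds, is how an amine, a fluorine atom or a methoxy group at this place would compare with hydrogen. On these data alone, the part played by the trifluoromethyl group also stays open.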